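The source may hold more compounds than are shown below. What is called first, only, known or untested is meant among the compounds shown, and "the series" means these compounds.

Measured so far in an assay on HEK293 cells for displacement of a labelled ligand from 5-hydroxytryptamine receptor 6 (Homo sapiens), with a stated time of 60 min, tested at 0.01 uM, in the presence of a further agent that is not named here; on this read-out lower numbers stand for a weaker effect and higher numbers for a stronger effect at the one concentration tested:
compound 1, `COc1ccc(S(=O)(=O)NCCN2CCC(CCC(=O)c3cc(Cl)c(N)cc3OC)CC2)cc1Br`: "not active" (no number reported)
compound 2, `COc1ccc(S(=O)(=O)NCCN2CCC(CCC(=O)c3cc(Cl)c(N)cc3OC)CC2)cc1OC`: 3%
compound 3, `COc1cc(N)c(Cl)cc1C(=O)CCC1CCN(CCNS(=O)(=O)c2ccc(N)cc2)CC1`: 7%

Among the measured compounds shown here, compound 3 stands beside compound 2 on these numbers; the only measured step, a number 4 percentage points higher from compound 2 to compound 3 (within the scatter), did not reach beyond the scatter, and compound 1 gave no number at all. So nothing measured here has produced a clear effect in this assay.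

Compound 4, `COc1cc(N)c(Cl)cc1C(=O)CCC1CCN(CCNS(=O)(=O)c2cc(Br)c(N)c(Br)c2)CC1`, is made from compound 3 by one change: 4-amino-3,5-dibromophenyl in place of 4-aminophenyl on a sulfonyl sulfur. For the measured compounds named here, no measured step changes this same part of the structure in this way, so the nearest guide is the general picture: the one step that does change the group on the sulfonyl sulfur, a number 4 percentage points higher from compound 2 to compound 3 (within the scatter), stayed within the scatter, and every measured compound sits low. The expected step of a number 1 percentage points higher from compound 3 to compound 4 (within the scatter) is therefore none beyond the scatter, with compound 4 expected to stay low. Compound 4 is estimated at 8%, within a range from 0% to 20%.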

Compound 4, a percentage reported as inhibition, at one concentration (the size of the read-out at that concentration, not a potency): 52%
For compound 4 the middle estimate is 44 percentage points below the measured one; measured number outside the range, above it.
By their numbers in this assay, from the lowest: compounds 2 and 3 (each within the scatter of the next); then compound 4.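

In this assay the group on the sulfonyl sulfur now clearly matters: the earlier change here stayed within the scatter, whereas 4-amino-3,5-dibromophenyl in place of 4-aminophenyl gives a number 45 percentage points higher from compound 3 to compound 4 (beyond the scatter) and marks the first clear effect in this series. The same group in place of 3,4-dimethoxyphenyl gives a number 49 percentage points higher from compound 2 to compound 4 (beyond the scatter) as well, so the result holds against both groups with a number. A bromine on this ring does not by itself ensure an effect, since compound 1, which also carries one, gives "not active" (no number reported) in this assay and goes against any such simple rule.

Nothing available here explains why the two bromine atoms have this effect. On these data alone, it remains open whether a single bromine would be enough, whether chlorine atoms or methyl groups could replace the two bromines, and whether the amine on this ring is needed.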